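The source may report more compounds than this note shows. Statements on the series, on what has been measured and on what is new or still open speak of the compounds shown alone.

Compounds measured so far:

Compound 1 `CNc1nc(N)nc2ccccc12` — 6.87 uM
Compound 2 `CCCNc1nc(N)nc2ccccc12` — 0.93 uM
Compound 3 `CCCCNc1nc(N)nc2ccc(F)cc12` — 0.1 uM

These three were measured in an ADME assay on HEK293 cells for agonist activity at Toll-like receptor 8 (Homo sapiens), read by a luciferase reporter, with a stated time of 6 h; a lower number here means that less compound is needed, a higher number that more compound is needed for the effect. Compound 3 gives the lowest number of the three; its nearest neighbour is compound 2, and compound 1 lies furthest from it, both gaps well beyond the scatter. Among the compounds with values here, the only step between measured compounds that differ in a single place runs from compound 1 to compound 2 and shows a 7.4-fold lower number from compound 1 to compound 2 (0.87 log units; beyond the scatter). Within the data shown here, compound 3 differs from compound 2 in two places, so no single step separates them.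

Compound 4 `CCCCNc1nc(N)nc2ccc(C(C)=O)cc12` has not been measured. It differs from compound 3 in one place: acetyl in place of fluoro on an aromatic carbon. Among the measured compounds shown here, no measured step touches this position on the ring; the step from compound 1 to compound 2 concerns the chain on the nitrogen and offers no guide here. With nothing to lean on, the expectation is a number close to that of compound 3, with only a small step, a 1.5-fold higher number from compound 3 to compound 4 (0.18 log units; within the scatter), expected in this assay. Compound 4 is therefore estimated at 0.15 uM, within a range of 0.03 uM to 0.8 uM.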

Compound 4, minimum effective concentration: 1.9 uM
Estimate against measurement, compound 4: 13-fold (1.10 log units) below; measured number outside the range, above it.
By their numbers in this assay, from the lowest: compound 3; then compound 2; then compound 4; then compound 1.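

Within the data shown here, this position on the ring, which no earlier step touched, proves sensitive to what it carries: in this assay, acetyl in place of fluoro on an aromatic carbon gives a 19-fold higher number from compound 3 to compound 4 (1.28 log units; beyond the scatter), so more compound is needed for the effect. The change swaps a lone fluorine for a larger group with a double bond outside the aromatic rings and a hydrogen-bond acceptor, and these features enter together. Nothing available shows which of them, if any, accounts for the step.

With only fluoro and acetyl shown here, it remains open how a methyl, a methoxy, a nitrile or an amine at this place would read. From the compounds shown here alone, it is also open whether the same step would appear with a shorter or longer chain on the nitrogen.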